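Trimming the Hexyl Chain of Compound 3

The source may report more compounds than this note shows. Statements on the series, on what has been measured and on what is new or still open speak of the compounds shown alone.

Of the compounds shown here, three have been measured in a functional assay on MDA-MB-231 cells (Homo sapiens) for antiproliferative activity, read by sulforhodamine B assay, with a stated time of 48 h; a lower number here means a stronger inhibitor of growth, a higher number a weaker inhibitor of growth. Among them, compound 3 `CCCCCCc1cn(CCCN2C(=O)COc3ccccc32)nn1`, which carries a hexyl group, gives 1100 nM, the lowest number of the three. Compound 1 `CCCCCc1ccc(-c2cn(CCCN3C(=O)COc4ccccc43)nn2)cc1`, with a pentyl group on an aromatic carbon, gives 5000 nM. Compound 2 `COc1ccc(-c2cn(CCCN3C(=O)COc4ccccc43)nn2)cc1`, with methoxy in place of that pentyl, gives 41500 nM.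

The next compound to be measured is compound 4 `CCCCc1cn(CCCN2C(=O)COc3ccccc32)nn1`. It differs from compound 3 in one place, with hydrogen in place of ethyl on a saturated chain carbon, four bonds along the chain from an aromatic carbon. The saturated chain stays but becomes shorter.

Among the measured compounds shown here, no measured step shortens a chain directly, so the evidence is indirect. Removing the pentyl group gave an 8.3-fold higher number from compound 1 to compound 2 (0.92 log units; beyond the scatter), while bringing in the hexyl group gave a 38-fold lower number from compound 2 to compound 3 (1.58 log units; beyond the scatter). Both steps lie beyond the scatter, and in both the compound with the saturated chain has the lower number. Those steps exchange whole groups, however, whereas this change keeps most of the chain. A smaller move towards a higher number is therefore expected in this assay, an estimated 2.7-fold higher number from compound 3 to compound 4 (0.44 log units; beyond the scatter). Compound 4 is estimated at 3000 nM, with an expected range from 1200 nM to 8000 nM.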

Compound 4, concentration for 50% growth inhibition: 3600 nM
For compound 4 the middle estimate is 1.2-fold (0.08 log units) below the measured one, and the stated range covers the measured number.
By their numbers in this assay, from the lowest: compound 3; then compounds 4 and 1 (each within the scatter of the next); then compound 2.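

In this assay, shortening the chain directly from hexyl to butyl gives a 3.3-fold higher number from compound 3 to compound 4 (0.51 log units; beyond the scatter) and so shows what the earlier whole-group exchanges could not: at this position, chain length alone changes the result, even when the saturated chain stays in place. Removing only the ethyl portion, on a saturated chain carbon four bonds along the chain from an aromatic carbon, is enough to produce a step beyond the usual scatter, yet the butyl chain still compares well with the 4-methoxyphenyl group, with a 12-fold lower number from compound 2 to compound 4 (1.06 log units; beyond the scatter) in the same direction as the step seen with hexyl. No measurement here explains why the number moves with either change.

With only butyl and hexyl compared directly, the data cannot tell whether the number changes smoothly with chain length, so a pentyl chain would help to fill that gap, while an octyl chain would test whether lengthening beyond hexyl continues to lower the number. As far as these compounds go, it also remains open whether the chain must be purely carbon, which a chain ending in an amine or a carboxylic acid would help to answer.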